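Replacing the hydroxycarbamoyl chain with pyrrolidin-1-yl

A few compounds are considered here, and "the series" means these few. Any claim that something is new, unique, unknown or untested is made for them only; others in the source may bear on it.

Measured in a functional assay on MDA-MB-231 cells (Homo sapiens) for inhibition, read by sulforhodamine B assay, with a stated time of 48 h; a lower number here means a stronger inhibitor of growth, a higher number a weaker inhibitor of growth:
- compound 1 `COc1ccc2c(c1)NC(=O)CN2c1nc(COC(C)=O)nc2ccccc12`: 8.95 nM
- compound 2 `COc1ccc2c(c1)NC(=O)CN2c1nc(OCC2CC2)nc2ccccc12`: 45.2 nM
- compound 3 `COc1ccc2c(c1)NC(=O)CN2c1nc(COCCCC(=O)NO)nc2ccccc12`: 1020 nM

Compound 3 has the highest number of the three at 1020 nM, so it is the weakest inhibitor of growth in this set. The next step leads to compound 4 `COc1ccc2c(c1)NC(=O)CN2c1nc(N2CCCC2)nc2ccccc12`, with pyrrolidin-1-yl in place of (3-(hydroxycarbamoyl)propoxy)methyl on an aromatic carbon, between two ring nitrogen atoms: pyrrolidin-1-yl in place of (3-(hydroxycarbamoyl)propoxy)methyl on an aromatic carbon.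

Three measured steps change this same place. Two are large and lead up to the chain: a 110-fold higher number from compound 1 to compound 3 (2.06 log units; beyond the scatter) and a 23-fold higher number from compound 2 to compound 3 (1.35 log units; beyond the scatter). The third, between the two groups without the chain, is modest: a 5.1-fold higher number from compound 1 to compound 2 (0.70 log units; beyond the scatter). Among the measured compounds shown here, no measured compound carries pyrrolidin-1-yl, so the data give only an indirect guide. If compound 4 behaves like compound 1 and compound 2, a large fall in the number is expected in this assay, and the expected step is a 26-fold lower number from compound 3 to compound 4 (1.41 log units; beyond the scatter). The estimate for compound 4 is 40 nM, with an expected range of 8 nM to 200 nM.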

Compound 4, concentration for 50% growth inhibition: 80.1 nM
Compound 4: middle estimate off by 2.0-fold (0.30 log units), on the low side, within the range that was stated.
By their numbers in this assay, from the lowest: compound 1; then compounds 2 and 4 (each within the scatter of the next); then compound 3.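

Notes on the position on the aromatic carbon between two ring nitrogen atoms: in this assay, a 13-fold lower number from compound 3 to compound 4 (1.10 log units; beyond the scatter) shows that a ring attached directly, pyrrolidin-1-yl, is accepted here in place of the (3-(hydroxycarbamoyl)propoxy)methyl chain. Pyrrolidin-1-yl and cyclopropylmethoxy cannot be told apart, with a 1.8-fold higher number from compound 2 to compound 4 (0.25 log units; within the scatter), whereas acetoxymethyl keeps an edge over pyrrolidin-1-yl, with an 8.9-fold higher number from compound 1 to compound 4 (0.95 log units; beyond the scatter), so compound 1 remains the strongest inhibitor of growth of the four. Nothing available on these compounds gives a reason for these differences.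

Open, as far as these compounds go, is whether a six-membered piperidine or morpholine ring, or an open-chain dimethylamino group, would match pyrrolidin-1-yl at this position. Also open, from the compounds shown here alone, is whether a carboxylic acid at the end of the chain would behave like the hydroxycarbamoyl end of compound 3.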